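Alkyne substituent swap on the shared fluorinated core

The source may report more compounds than this note shows. Statements on the series, on what has been measured and on what is new or still open speak of the compounds shown alone.

For the measured compounds named here, compound 1 `CCN[C@H](C#Cc1c(F)ccc2c1/C(=C/c1[nH]ccc1OC)C(=O)N2)CO` and compound 2 `COc1cc[nH]c1/C=C1\C(=O)Nc2ccc(F)c(C#C[C@@H](NS(C)(=O)=O)[C@@H](C)O)c21` are the two measured members here. In a functional assay on MDA-MB-435 cells (Homo sapiens) for inhibition (a lower number here means a stronger inhibitor, a higher number a weaker inhibitor), compound 1 gives 1160 nM; in this assay compound 2 gives 2630 nM. Going by the values given here, the single measured step is a 2.3-fold higher number from compound 1 to compound 2 (0.36 log units; beyond the scatter), so compound 2 stands with the higher of the two numbers.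

Compound 3 `COc1cc[nH]c1/C=C1\C(=O)Nc2ccc(F)c(C#C[C@@H]3C[C@@H](O)CN3)c21` is not yet measured. It differs from compound 2 by 4-hydroxypyrrolidin-2-yl in place of 2-hydroxy-1-(methanesulfonamido)propyl on a triple-bonded carbon. Among the compounds with values here, the one step that bears on this change is a 2.3-fold higher number from compound 1 to compound 2 (0.36 log units; beyond the scatter): it exchanged the substituent on the same triple-bonded carbon, and the 4-hydroxypyrrolidin-2-yl group that now enters shares with compound 1 a nitrogen bearing hydrogen together with a hydroxyl group, while the methanesulfonamido group of compound 2 leaves. A step back of roughly that size, toward a lower number in this assay, is therefore expected, with the caveat that the scatter could absorb part of it. The expected step is a 2.2-fold lower number from compound 2 to compound 3 (0.34 log units; beyond the scatter). For compound 3 the estimate in this assay is 1200 nM, with a range from 450 nM to 3200 nM.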

Compound 3, half-maximal inhibitory concentration: 63 nM
Estimate against measurement, compound 3: 19-fold (1.28 log units) above; measured number outside the range, below it.
By their numbers in this assay, from the lowest: compound 3; then compound 1; then compound 2.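

In this assay, for the compounds shown here, the substituent on this triple-bonded carbon matters far more than the first pair suggested: the 4-hydroxypyrrolidin-2-yl group gives a 42-fold lower number from compound 2 to compound 3 (1.62 log units; beyond the scatter) and also an 18-fold lower number from compound 1 to compound 3 (1.27 log units; beyond the scatter) and both steps dwarf a 2.3-fold higher number from compound 1 to compound 2 (0.36 log units; beyond the scatter) as the only earlier measure of change at this position. Compound 1 also carries a nitrogen bearing hydrogen and a hydroxyl group, so among these three compounds the presence of those two features alone does not go with the lowest number, which belongs to the compound holding them in a five-membered non-aromatic ring. The data shown give no measured basis for explaining the size of these steps.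

On these data alone, what remains open is whether the gain follows the ring itself or the ring together with its hydroxyl group, a question that plain pyrrolidin-2-yl, piperidin-2-yl or an N-methyl-4-hydroxypyrrolidin-2-yl group would address. The weight of the two defined stereocentres is also unsettled, and the other stereoisomers of the 4-hydroxypyrrolidin-2-yl group would be needed to settle it.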